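Thiosemicarbazone Arylidene Swap: Methoxyphenyl to Nitrophenyl

The compounds below may be only part of what the source reports. "The series", "measured", "known", "first", "only" and "open" are said of these compounds alone.

The account begins with compound 1 `CC1=CC[C@@H]([C@@](C)(O)CCCC(C)(C)NC(=S)NN)CC1`, which in a functional assay on MCF7 cells (Homo sapiens) for cytotoxicity, read by sulforhodamine B assay (on this read-out higher numbers stand for weaker inhibition of growth and lower numbers for stronger inhibition of growth), gives 15300 nM. Compound 2 `COc1ccc(/C=N\NC(=S)NC(C)(C)CCC[C@](C)(O)[C@@H]2CC=C(C)CC2)cc1` gives 6500 nM in this assay, the lowest of the two numbers shown, and the step of a 2.4-fold lower number from compound 1 to compound 2 (0.37 log units; beyond the scatter) is the only measured one. Compound 3 `CC1=CC[C@@H]([C@@](C)(O)CCCC(C)(C)NC(=S)N/N=C\c2ccccc2[N+](=O)[O-])CC1`, not yet measured, differs from compound 2 by 2-nitrophenyl in place of 4-methoxyphenyl on a carbon with a double bond to nitrogen. For the measured compounds named here, no measured step bears directly on this change: the single measured step concerns the introduction of the whole arylidene group rather than an exchange of one aryl substituent for another, so nothing here shows how 2-nitrophenyl compares with 4-methoxyphenyl. On that basis compound 3 is expected to give a number close to that of compound 2, with the estimated step of no change at the digits printed from compound 2 to compound 3 (within the scatter) judged as none beyond the scatter. The estimate for compound 3 in this assay is therefore 6500 nM, with a range from 2500 nM to 17000 nM.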

Compound 3, concentration for 50% growth inhibition: 18600 nM
Compound 3: middle estimate off by 2.9-fold (0.46 log units), on the low side; the measured number lies above the stated range.
By their numbers in this assay, from the lowest: compound 2; then compounds 1 and 3 (each within the scatter of the next).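

In this assay the aryl group on the carbon with a double bond to nitrogen proves not to be interchangeable: 2-nitrophenyl in place of 4-methoxyphenyl gives a 2.9-fold higher number from compound 2 to compound 3 (0.46 log units; beyond the scatter). Compound 3 also stands within the scatter of compound 1, which has no arylidene group, so the lower number of compound 2 does not come with every arylidene group among these compounds. Nothing available explains why the number rises with this exchange.

The exchange alters both the substituent and where it sits on the ring, and the compounds shown do not separate these two changes. Also open, as far as these compounds go, is where an unsubstituted phenyl, or an aryl group carrying an amine or a carboxylic acid, would fall relative to compound 2 and compound 3.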